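Methoxy to Trifluoromethyl: What Compound 4 Might Show

The compounds below may be only part of what the source reports. "The series", "measured", "known", "first", "only" and "open" are said of these compounds alone.

Compound 1 `CCC(C(=O)N1CCN(c2ccccc2Cl)CC1)N1C(=O)CCC1=O` — 50%
Compound 2 `CCC(C(=O)N1CCN(c2cccc(OC)c2)CC1)N1C(=O)CCC1=O` — 0%
Compound 3 `CCC(C(=O)N1CCN(c2ccc(F)cc2)CC1)N1C(=O)CCC1=O` — 25%

Three compounds on a shared core, differing only in the aromatic group carried on an amine nitrogen in a ring, were tested in a functional assay on the whole organism (strain Swiss) with Mus musculus as the target, in the maximal electroshock model, with a stated time of 1 h, at a dose of 300 mg/kg by the intraperitoneal route; a higher number here means a stronger effect of the compound at the dose given, a lower number a weaker effect. Compound 2 stands lowest of the three numbers. Its nearest neighbour is compound 3, reached by a number 25 percentage points higher from compound 2 to compound 3 (beyond the scatter); its furthest is compound 1, from which it is separated by a number 50 percentage points lower from compound 1 to compound 2 (beyond the scatter). The remaining pair moved by a number 25 percentage points lower from compound 1 to compound 3 (beyond the scatter). Every change of the aromatic group so far has shifted the read-out beyond the scatter, by a modest to large amount.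

Compound 4 `CCC(C(=O)N1CCN(c2cccc(C(F)(F)F)c2)CC1)N1C(=O)CCC1=O` has not yet been measured. It differs from compound 2 by trifluoromethyl in place of methoxy on an aromatic carbon. For the measured compounds named here, no measured step exchanges a group at this same place, so the three aromatic-group steps are the only guide, and they say that such changes typically move the number by a modest to large amount. Starting from the floor at compound 2, the step can only go upward or stay flat. The step from compound 2 to compound 4 is therefore expected to be a number 25 percentage points higher from compound 2 to compound 4 (beyond the scatter). Compound 4 is estimated at 25%, with a range from 0% to 50%.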

Compound 4, a percentage reported as activity, at one dose (the size of the read-out at that dose, not a potency): 100%
Compound 4: the middle estimate sits 75 percentage points below what was measured; measured number above the stated range.
By their numbers in this assay, from the lowest: compound 2; then compound 3; then compound 1; then compound 4.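

In this assay, the step is a number 100 percentage points higher from compound 2 to compound 4 (beyond the scatter), so a single exchange of methoxy for trifluoromethyl on an aromatic carbon, meta to a large group, spans the whole distance from no effect to the top of the series. The earlier compounds shown here could not show this, since each of their steps changed both the group on the aromatic ring and where it stood, whereas here the place stays fixed and only the group differs. This one place can therefore hold both the lowest number of the series, in compound 2 (0%), and a number that stands above those of compound 1 (50%) and compound 3 (25%), and nothing given here explains the size of this step.

Going by these compounds, whether a nitrile, a methyl group or an amine at this same place would sit nearer compound 2 or compound 4 remains open, as does whether trifluoromethyl would give a similar number on another aromatic carbon of the ring. On these data alone, each number is also a reading at one dose rather than a potency, so how compound 4 would rank at lower doses is unknown.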